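This account rests on a few compounds, and the source may have more. Where it says the series, first, only, none or still open, it means among the compounds named here.

For the measured compounds named here, in a functional assay on SK-BR-3 cells (Homo sapiens) for antiproliferative activity, read by MTT assay, with a stated time of 72 h (on this read-out higher numbers stand for weaker inhibition and lower numbers for stronger inhibition), compound 3 (`C/C=C1/[C@H](O[C@@H]2O[C@H](CO)[C@@H](O)[C@H](O)[C@H]2O)OC=C(C(=O)OC)[C@H]1CC(=O)OCCc1ccc(O)c(O)c1`) gives 160000 nM as the only actual number. Compound 1 (`C/C=C1/[C@H](O[C@@H]2O[C@H](CO)[C@@H](O)[C@H](O)[C@H]2O)OC=C(C(=O)OC)[C@H]1CC(=O)OCCc1ccc2c(c1)OCCO2`) stands at > 20000 nM as a limit. Compound 2 (`C=C(C)CCOC(=O)C[C@@H]1C(C(=O)OC)=CO[C@@H](O[C@@H]2O[C@H](CO)[C@@H](O)[C@H](O)[C@H]2O)/C1=C/C`) stands at > 15000 nM as a limit too. Compound 4 (`C/C=C1/[C@H](O[C@@H]2O[C@H](CO)[C@@H](O)[C@H](O)[C@H]2O)OC=C(C(=O)OC)[C@H]1CC(=O)OCCc1ccc([N+](=O)[O-])cc1`) carries 4-nitrophenyl in place of 3,4-dihydroxyphenyl on a saturated chain carbon, two bonds along the chain from an oxygen next to a carbonyl group. The measured changes at that place (a step that the limit leaves unreadable from compound 1 to compound 3; a step that the limit leaves unreadable from compound 2 to compound 3; a step that the two limits leave unreadable from compound 1 to compound 2) supply no size. The expectation therefore rests on compound 3 at 160000 nM alone and leans modestly toward stronger inhibition in this assay with wide uncertainty. The estimate is a 3.2-fold lower number from compound 3 to compound 4 (0.51 log units; beyond the scatter) in that direction. Compound 4 is expected at 50000 nM within an estimated range from 12000 nM to 200000 nM in this read-out.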

Compound 4, half-maximal inhibitory concentration: > 20000 nM
Compound 4: no number, only a limit; the forecaster's own chance of this, stated with the estimate: 60%; the middle value does not contradict the limit.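

In this assay compound 4 gives only a limit, > 20000 nM. Its steps from compound 1, compound 2 and compound 3 therefore cannot be read. On these data alone, how far the groups at this place differ in inhibition remains open.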